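The compounds below may be only part of what the source reports. "The series", "measured", "known", "first", "only" and "open" are said of these compounds alone.

Measured compounds and their values:

Compound 1 `OCCNc1nnc2nncn2n1` — in a functional assay on BeWo cells (Homo sapiens) for inhibition, read by MTT assay, with a stated time of 72 h (a higher number here means a weaker inhibitor, a lower number a stronger inhibitor), compound 1 gives 3310 nM.
Compound 2 `CC(=O)N1CCN(c2nnc3nncn3n2)CC1` — in this assay compound 2 gives 13100 nM.
Compound 3 `c1nnc2nnc(NC3CCCCC3)nn12` — in this assay compound 3 gives 2650 nM.

Among these three, compound 2 stands at the highest number, and the gaps to compound 1 and to compound 3 both lie beyond the usual scatter, so compound 2 is the weakest inhibitor of the set in this assay. Within the data shown here, the three compounds share a core and differ in the group attached to it; no single-point step between any two of them is available, so only their values can be compared.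

Compound 4 `CC(C)C(=O)N1CCN(c2nnc3nncn3n2)CC1` is not yet measured. Compound 4 differs from compound 2 in one place: isopropyl in place of methyl on a carbonyl carbon. Among the measured compounds shown here, the change is small, and nothing among the measured compounds shows how such a change acts on this core. The step from compound 2 to compound 4 is therefore expected to be modest, a 1.5-fold lower number from compound 2 to compound 4 (0.16 log units; within the scatter), with a small move toward a lower number as the more likely direction but no confident move beyond the scatter. Compound 4 is accordingly estimated at 9000 nM, within a range from 3500 nM to 25000 nM.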

Compound 4, half-maximal inhibitory concentration: 1090 nM
For compound 4 the middle estimate is 8.3-fold (0.92 log units) above the measured one; measured number outside the range, below it.
By their numbers in this assay, from the lowest: compound 4; then compounds 3 and 1 (each within the scatter of the next); then compound 2.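

In this assay, among these compounds, the first step between two compounds that differ in one place is a 12-fold lower number from compound 2 to compound 4 (1.08 log units; beyond the scatter), a large move where the earlier compounds showed no single change at all. It shows that this position, on a carbonyl carbon whose other neighbour is an amide-type nitrogen in a ring, is sensitive: going from acetyl to isopropylcarbonyl adds no ring, no hydrogen-bond donor or acceptor and no net charge, yet the number falls well beyond the scatter. Nothing at hand accounts for the size of this step.

From the compounds shown here alone, whether a longer chain, a tert-butyl group or a cyclopropyl ring on the same carbonyl carbon would move the number further or reverse the step remains open. So does whether an amine in that place would keep the lower number.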